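The source may hold more compounds than are shown below. What is called first, only, known or untested is meant among the compounds shown, and "the series" means these compounds.

Compound 1 `O=C(OCc1ccc(F)cc1)c1cccc(=O)[nH]1` gives 3000 nM in an assay on isolated protein for inhibition of matrix metalloproteinase-9 (Homo sapiens); on this read-out higher numbers stand for weaker inhibition and lower numbers for stronger inhibition.
Compound 2 `COc1cccc(COC(=O)c2cccc(S)n2)c1` gives 93000 nM in this assay.
Compound 3 `O=C(OCc1cccc(Cl)c1)c1cccc(=O)[nH]1` gives 67000 nM in this assay.

Compound 2 carries the highest of the three numbers, yet its gap to compound 3 lies within the scatter, while compound 1 sits far lower, beyond it. The unmeasured compound 4 `O=C(OCc1cccc(-c2ccccc2)c1)c1cccc(S)n1` differs from compound 2 in one place: phenyl in place of methoxy on an aromatic carbon. Among the compounds with values here, no pair of measured compounds shows this change, so no measured step anchors the expectation. A modest step toward a lower number is expected, namely a 1.9-fold lower number from compound 2 to compound 4 (0.27 log units; within the scatter). Compound 4 is therefore estimated at 50000 nM in this assay, within a range from 10000 nM to 250000 nM.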

Compound 4, half-maximal inhibitory concentration: 50000 nM
Compound 4: the middle estimate sits on the measured number at the digits printed; measured number inside the range.
By their numbers in this assay, from the lowest: compound 1; then compounds 4, 3 and 2 (each within the scatter of the next).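

In this assay, replacing methoxy with phenyl, meta to a large group, gives a 1.9-fold lower number from compound 2 to compound 4 (0.27 log units; within the scatter). This is the first change shown at this position, and it indicates that a six-membered aromatic ring of six heavy atoms can replace a two-atom group without a shift beyond the scatter. Nothing available explains this small step. From the compounds shown here alone, whether an amine or a carboxylic acid at this position would move the number beyond the scatter remains open, as does whether phenyl would behave the same way on the core of compound 1, which gives 3000 nM.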